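Swapping a benzyl for an isopropyl on a fused core

The source may hold more compounds than are shown below. What is called first, only, known or untested is meant among the compounds shown, and "the series" means these compounds.

Of the compounds shown here, three of one family have been measured so far. Compound 1 `CC(=O)c1ccc2c(c1)C1CNCC2C1` gives 0.17 nM in an assay on HEK293 cells for binding affinity to Neuronal acetylcholine receptor; alpha4/beta2 (Homo sapiens); on this read-out lower numbers stand for stronger inhibition and higher numbers for weaker inhibition. Compound 2 `c1ccc(Cc2nc3cc4c(cc3o2)C2CNCC4C2)cc1` gives 34 nM in this assay, and compound 3 `FC(F)(F)c1cccc2c1C1CNCC2C1` gives 39 nM. Among these three numbers compound 2 stands second highest: its nearest neighbour is compound 3, whose number is only slightly higher and within the usual scatter of such measurements, while compound 1 lies far away, with a much lower number that is well beyond the scatter.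

Compound 4 `CC(C)c1nc2cc3c(cc2o1)C1CNCC3C1` has not yet been measured. It differs from compound 2 in one place: isopropyl in place of benzyl on an aromatic carbon. For the measured compounds named here, no pair of already measured compounds shows this same change, so there is no direct precedent to lean on. Given that the rest of the molecule is unchanged and that compound 2 sits at 34 nM, the expectation is a modest step, and a step of a 1.4-fold lower number from compound 2 to compound 4 (0.13 log units; within the scatter) is estimated, without a clear direction beyond the scatter. Compound 4 is therefore expected to give about 25 nM in this assay, with a range from 5 nM to 120 nM.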

Compound 4, inhibition constant: 1.9 nM
Compound 4: the middle estimate sits 13-fold (1.12 log units) above what was measured, outside the stated range (below it).
By their numbers in this assay, from the lowest: compound 1; then compound 4; then compounds 2 and 3 (each within the scatter of the next).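

In this assay, the exchange of benzyl for isopropyl on the aromatic carbon of the five-membered aromatic ring gives an 18-fold lower number from compound 2 to compound 4 (1.25 log units; beyond the scatter) and is a large step. For the compounds shown here, this is the first pair in the family that differs in one place, and it shows that the group on this carbon can by itself change the number well beyond the scatter, with the smaller, ring-free isopropyl giving the lower number in this pair. The change removes a six-membered aromatic ring and reduces the group from 7 heavy atoms to 3, and no measurement shown explains why the number falls.

With only these two groups at this carbon, a single step cannot separate the loss of the aromatic ring from the drop in heavy atoms, and it cannot show how far the trend would run. A methyl group, a cyclohexylmethyl group with its saturated ring, or an amine at the same carbon would help to tell these possibilities apart.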